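The source may report more compounds than this note shows. Statements on the series, on what has been measured and on what is new or still open speak of the compounds shown alone.

- compound 1 `CC=C(/C=C/c1ccc(OC)c(N)c1)c1cc(OC)c(OC)c(OC)c1` at 137 nM
- compound 2 `CC=C(/C(C)=C/c1ccc(OC)c(O)c1)c1cc(OC)c(OC)c(OC)c1` at 505 nM

In a functional assay on A2780 cells (Homo sapiens) for antiproliferative activity, read by MTT assay, with a stated time of 48 h (on this read-out higher numbers stand for weaker inhibition and lower numbers for stronger inhibition), compound 2 has the higher number of the two at 505 nM and so is the weaker inhibitor, while compound 1 stands at 137 nM on the stronger side. The gap between these two lies beyond the usual scatter. Compound 3 `CCCC=C(/C(C)=C/c1ccc(OC)c(O)c1)c1cc(OC)c(OC)c(OC)c1` differs from compound 2 in one place, ethyl in place of hydrogen on a saturated chain carbon bound to a double-bonded chain carbon with ethyl in place of hydrogen on a saturated chain carbon bound to a double-bonded chain carbon. Among the measured compounds shown here, no measured pair shows this change, so its size is uncertain. A modest weakening is expected, estimated as a 1.6-fold higher number from compound 2 to compound 3 (0.20 log units; within the scatter) in this assay for now. For compound 3 the estimated value is 800 nM within a range of 250 nM to 2500 nM as a first guess.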

Compound 3, half-maximal inhibitory concentration: 2930 nM
Compound 3: the middle estimate sits 3.7-fold (0.56 log units) below what was measured, outside the stated range (above it).
By their numbers in this assay, from the lowest: compound 1; then compound 2; then compound 3.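

In this assay, the saturated chain carbon bound to a double-bonded chain carbon proves sensitive to change: ethyl in place of hydrogen there gives a 5.8-fold higher number from compound 2 to compound 3 (0.76 log units; beyond the scatter), a loss beyond the usual scatter. This carbon therefore does not freely accept added chain length, at least for this one change. Nothing available here explains the loss.

On these data alone, whether methyl, a longer chain such as butyl, or an amine on this carbon would cost as much remains open. So does whether ethyl would cost as much on the core of compound 1.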